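The source may report more compounds than this note shows. Statements on the series, on what has been measured and on what is new or still open speak of the compounds shown alone.

Measured so far:
compound 1 `O=C(CSc1nnc(-c2ccncc2)o1)N/N=C/c1ccc(Cl)cc1` — 17000 nM
compound 2 `O=C(CSc1nnc(-c2ccncc2)o1)N/N=C/c1ccccc1[N+](=O)[O-]` — 30700 nM

Both compounds share a core and differ only in the group on the carbon with a double bond to nitrogen. In a functional assay on SW 1116 cells (Homo sapiens) for cytotoxicity, read by MTT assay, with a stated time of 48 h (a higher number here means a weaker inhibitor, a lower number a stronger inhibitor), compound 1 gives 17000 nM and compound 2 gives 30700 nM. Going by the values given here, compound 2 holds the highest of the two numbers, but the only step measured, a 1.8-fold higher number from compound 1 to compound 2 (0.26 log units; within the scatter), is within the scatter, so the two values cannot be told apart.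

Compound 3 `O=C(CSc1nnc(-c2ccncc2)o1)N/N=C/C=C/c1ccccc1` is not yet measured. It differs from compound 2 by 2-phenylethenyl in place of 2-nitrophenyl on a carbon with a double bond to nitrogen. Among the compounds with values here, the one step seen so far bears on this change only loosely: it swapped one six-membered aromatic ring for another on the same carbon and moved the number by a 1.8-fold higher number from compound 1 to compound 2 (0.26 log units; within the scatter), nothing beyond scatter. Within the data shown here, no step exchanging a ring for 2-phenylethenyl exists in this set, so there is no basis for expecting a move beyond scatter in either direction in this assay.

The step of a 1.2-fold lower number from compound 2 to compound 3 (0.09 log units; within the scatter) is therefore expected to fall within the scatter. Compound 3 is estimated at 25000 nM, with a range from 8000 nM to 70000 nM.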

Compound 3, half-maximal inhibitory concentration: 14900 nM
The estimate for compound 3 lay 1.7-fold (0.22 log units) above the measured number, within the range that was stated.
By their numbers in this assay, from the lowest: compounds 3, 1 and 2 (each within the scatter of the next, the first and the last beyond it).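

In this assay the carbon with a double bond to nitrogen now gives its first step beyond the scatter: a 2.1-fold lower number from compound 2 to compound 3 (0.31 log units; beyond the scatter) with 2-phenylethenyl in place of 2-nitrophenyl, a modest change. The same entering group in place of 4-chlorophenyl gives a 1.1-fold lower number from compound 1 to compound 3 (0.06 log units; within the scatter) and so separates nothing, which means the 2-phenylethenyl swap reads differently depending on the group it replaces, and compound 1 cannot be told apart from compound 3. Only compound 2 and compound 3 are resolved here, while compound 1 lies within the scatter of both, so this place accepts an aromatic ring on that carbon or 2-phenylethenyl with little overall spread in the numbers. Nothing available accounts for the step between compound 2 and compound 3.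

The compounds shown leave open whether a group without an aromatic ring on this carbon, such as a saturated alkyl chain or an amine, would stay in the same range. They also leave open whether a carboxylic acid or a methoxy group on the phenyl ring of 2-phenylethenyl would move the number beyond the scatter.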